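The source may report more compounds than this note shows. Statements on the series, on what has been measured and on what is new or still open speak of the compounds shown alone.

- compound 1 `COc1ccc(-c2c(Nc3cccc(C(F)(F)F)c3)c3ccc(OC)cc3oc2=O)cc1` gives 41200 nM
- compound 2 `COc1ccc(-c2c(Nc3ccc(NC(C)=O)cc3)c3ccc(O)cc3oc2=O)cc1` gives "not determined" (no result reported)

These results come from a functional assay on HCT-116 cells (Homo sapiens) for antiproliferative activity, read by MTT assay, with a stated time of 48 h (a lower number here means a stronger inhibitor, a higher number a weaker inhibitor), in which compound 2 has no number at all, so it offers no measured starting point. Compound 3 `COc1ccc(-c2c(Nc3cccc(C(F)(F)F)c3)c3ccc(O)cc3oc2=O)cc1` is the next structure to consider. The change is 3-(trifluoromethyl)phenyl in place of 4-acetamidophenyl on a nitrogen on an aromatic ring, with 3-(trifluoromethyl)phenyl in place of 4-acetamidophenyl on a nitrogen on an aromatic ring. The size of this step cannot be measured from compound 2. Within the data shown here, compound 1, which also carries 3-(trifluoromethyl)phenyl, gives 41200 nM as the only available number, and compound 3 is expected to lie within the usual scatter of it. For compound 3 the estimated value is 30000 nM, with an expected range from 10000 nM to 80000 nM.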

Compound 3, half-maximal inhibitory concentration: 55900 nM
For compound 3 the middle estimate is 1.9-fold (0.27 log units) below the measured one; the measured number falls inside the stated range.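

In this assay, hydrogen in place of methyl on an oxygen on an aromatic ring, with 3-(trifluoromethyl)phenyl kept on the nitrogen, gives a 1.4-fold higher number from compound 1 to compound 3 (0.13 log units; within the scatter), so at this position the two compounds cannot be told apart. Going by these compounds, the step between compound 2 and compound 3 cannot be read, and the effect of exchanging 4-acetamidophenyl stays unknown. Nothing available bears on why this result arises. On these data alone, what remains open is whether a longer chain or a carboxylic acid on that oxygen, or an amine on the phenyl ring, would shift the number beyond the scatter.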